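A few compounds are considered here, and "the series" means these few. Any claim that something is new, unique, unknown or untested is made for them only; others in the source may bear on it.

Compound 1 `O=C(Nc1ccccc1)O/N=C(\C1CCCCC1)C(CN1CCc2ccccc2C1)C1CCCCC1` gives > 1000 nM in an assay on isolated protein for displacement of a labelled ligand from metabotropic glutamate receptor 5 (Rattus norvegicus) (on this read-out higher numbers stand for weaker inhibition and lower numbers for stronger inhibition), which is a limit of the assay.
Compound 2 `Cc1nccn1CC(/C(=N/OC(=O)Nc1cccc(Cl)c1)C1CCCCC1)C1CCCCC1` gives > 1000 nM in this assay, likewise a limit.
Compound 3 `O=C(Nc1cccc(Cl)c1)O/N=C(\C1CCCCC1)C(Cc1ccncc1)C1CCCCC1` gives 117 nM in this assay.

Compound 3 is therefore the only one of the three with a number in this assay; the other two sit at the limit of > 1000 nM in this assay, at which 2 of the 3 values shown sit. Within the data shown here, the single measured step that touches the group on the saturated chain carbon is an at least 8.5-fold lower number from compound 2 to compound 3 (0.93 log units; beyond the scatter), and it moved the read-out from a limit to a number, so the choice of ring at that place clearly matters. The unmeasured compound 4 `O=C(Nc1cccc(Cl)c1)O/N=C(\C1CCCCC1)C(Cc1ccccc1)C1CCCCC1` differs from compound 3 by phenyl in place of pyridin-4-yl on a saturated chain carbon, two bonds along the chain from a carbon with a double bond to nitrogen and a saturated ring carbon. Among the measured compounds shown here, no measured pair shows phenyl at this place, so there is no direct precedent for the step; what the data show is only that one exchange of this ring was large. Compound 4 is accordingly expected to sit somewhat weaker than compound 3, with the estimated step of a 3.0-fold higher number from compound 3 to compound 4 (0.48 log units; beyond the scatter) carrying a wide range and a real chance of returning a limit instead of a number. Compound 4 is estimated at 350 nM, within 90 nM to 1500 nM.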

Compound 4, inhibition constant: 16 nM
Beside the measured number, compound 4's estimate is 22-fold (1.34 log units) above it; the measured number lies below the stated range.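

At this place on the saturated chain carbon, the exchange of pyridin-4-yl for phenyl gives a 7.3-fold lower number from compound 3 to compound 4 (0.86 log units; beyond the scatter) in this assay, so the ring nitrogen of pyridin-4-yl is not needed for binding to be measured here, and a ring of carbon only does better than it. Among these compounds, the earlier compounds showed only that pyridin-4-yl gave a number where 2-methyl-1H-imidazol-1-yl did not, which left open whether any ring at this place could do better than pyridin-4-yl; among the three groups compared on this core, phenyl now gives the lowest number. The largest step at this place, an at least 62-fold lower number from compound 2 to compound 4 (1.79 log units; beyond the scatter), starts from a limit and not a number, so its true size stays unknown: the limit of > 1000 nM in this assay, at which 2 of the 4 values shown sit.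

The compounds shown leave open whether pyridin-4-yl falls short of phenyl through the presence of a ring nitrogen as such or through where that nitrogen sits, which pyridin-3-yl or pyridin-2-yl at the same place would address. They also leave open whether an aromatic ring is needed at all, as a cyclohexyl ring or a plain propyl chain here would show, and whether a fluorine or methoxy group on the phenyl ring would lower the number further.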